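Dimethylamino in place of (tert-butyl)amino: working notes

The source may report more compounds than this note shows. Statements on the series, on what has been measured and on what is new or still open speak of the compounds shown alone.

- Compound 1 `O=C(c1ccccc1)N(N=C1C(Cl)=C(Cl)C(Cl)=C1Cl)C(=O)c1ccccc1` gives 800 nM
- Compound 2 `CC(C)(C)NN=C1C(Cl)=C(Cl)C(Cl)=C1Cl` gives > 3000 nM
- Compound 3 `Fc1ccccc1NN=C1C(Cl)=C(Cl)C(Cl)=C1Cl` gives > 3000 nM

All three were read in a functional assay on RPMI-8226 cells (Homo sapiens) for cytotoxicity, read by MTT assay, with a stated time of 48 h (on this read-out higher numbers stand for weaker inhibition and lower numbers for stronger inhibition), and share one core. For compound 2 the entry > 3000 nM is a limit and not a number. Compound 2 thus stands at the limit of > 3000 nM in this assay, at which 2 of the 3 values shown sit, and has no exact position. For compound 3 the entry > 3000 nM is also a limit.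

Compound 4 `CN(C)N=C1C(Cl)=C(Cl)C(Cl)=C1Cl` carries dimethylamino in place of (tert-butyl)amino on a double-bonded nitrogen and remains unmeasured. Going by the values given here, no measured step covers this change, so in this assay no shift beyond the scatter is expected, and no direction is favoured. The estimated step is a step that the limit leaves unreadable from compound 2 to compound 4 and it is expected to stay within the scatter. Compound 4 is estimated at 3500 nM (expected range 1200 nM to 10000 nM)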

Compound 4, half-maximal inhibitory concentration: >= 1300 nM
Compound 4 gave a limit, no number (the forecaster's own chance of this, stated with the estimate: 65%); the middle value does not contradict the limit.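

Going by these compounds alone, compound 2 and compound 4 both give limits, not numbers; no step between them can be read. The compounds shown leave open whether dimethylamino in place of (tert-butyl)amino on a double-bonded nitrogen changes the read-out at all, and in which direction.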